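Fluoro in place of chloro: Vero cytotoxicity outlook

A few compounds are considered here, and "the series" means these few. Any claim that something is new, unique, unknown or untested is made for them only; others in the source may bear on it.

Measured so far:
compound 1 `O=C(N/N=C/c1ccc(Cl)cc1)c1cccnc1`, in an ADME assay on Vero cells (Chlorocebus sabaeus) for cytotoxicity, read by microscopy (a higher number here means that more compound is tolerated, a lower number that less compound is tolerated), compound 1 gives > 100 ug/mL, a limit of the assay rather than a number.
compound 2 `O=C(N/N=C/c1cccc(Br)c1)c1cccnc1`, in this assay compound 2 gives >= 100 ug/mL, again a limit rather than a number.

Among the measured compounds shown here, compound 1 therefore stands only at the limit of > 100 ug/mL in this assay, at which 1 of the 2 values shown sits; the one other value shown is likewise a limit, (the limit of >= 100 ug/mL in this assay, at which 1 of the 2 values shown sits), so neither compound yields a number and no ordering between them can be drawn.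

The unmeasured compound 3 `O=C(N/N=C/c1ccc(F)cc1)c1cccnc1` differs from compound 1 in one place: fluoro in place of chloro on an aromatic carbon. For the measured compounds named here, no measured step between compounds is available in this assay to calibrate this change, and the two values in hand sit at the limits. The expectation is that a number no higher from compound 1 to compound 3 (the limit leaves the size open) stays within the scatter, with no shift either way. Compound 3 is accordingly estimated at 100 ug/mL, between 50 ug/mL and 200 ug/mL, most likely reported again only as a limit.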

Compound 3, minimum cytotoxic concentration: > 100 ug/mL
Compound 3 ended at the assay's limit; the forecaster's own chance of this, stated with the estimate: 80%; the middle value sits exactly at the limit.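

In this assay compound 1 and compound 3 both stand at a limit, so no step from chloro to fluoro can be read between them: the limit of > 100 ug/mL in this assay, at which 2 of the 3 values shown sit.

Left open is how far tolerance in this assay extends for either compound, and whether fluoro and chloro differ at all.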